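Trimming a large aromatic substituent to a short acid chain

The source may report more compounds than this note shows. Statements on the series, on what has been measured and on what is new or still open speak of the compounds shown alone.

Compounds measured so far:
compound 1, `Cc1noc(NS(=O)(=O)c2ccc(N/C(S)=N/c3ccccc3)cc2)c1C`: 4100 nM
compound 2, `Cc1noc(NS(=O)(=O)c2cccc3c(NC(C)C)cccc23)c1C`: 20 nM

In an assay on VSM-A10 cells for antagonist activity at Endothelin-1 receptor (Rattus norvegicus) (a lower number here means a stronger inhibitor, a higher number a weaker inhibitor), compound 1 gives 4100 nM, the highest of the two numbers recorded, and so the weaker of the two. Among the measured compounds shown here, the nearest point of comparison is compound 2, whose value in this assay is 20 nM; the gap between them is far beyond the ordinary scatter of repeated measurements, but the two compounds differ in more than one place, so no single step is set out for them.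

The compound not yet measured is compound 3, `Cc1noc(NS(=O)(=O)c2ccc(NCC(=O)O)cc2)c1C`. Relative to compound 1 the change is a group of 4 heavy atoms (2 carbon, 2 oxygen; no ring) in place of a group of 9 heavy atoms (7 carbon, 1 nitrogen, 1 sulfur; one six-membered aromatic ring of carbon only), on a nitrogen on an aromatic ring, so a large substituent is replaced by a short chain ending in an acid.

For the measured compounds named here, no step between measured compounds covers a change of this kind, so the direction is open. The expected step of a 2.1-fold lower number from compound 1 to compound 3 (0.31 log units; beyond the scatter) is modest, leaning toward a somewhat lower number. Compound 3 is expected to come out near 2000 nM, within a range from 300 nM to 15000 nM.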

Compound 3, half-maximal inhibitory concentration: 12000 nM
Beside the measured number, compound 3's estimate is 6.0-fold (0.78 log units) below it, within the range that was stated.
By their numbers in this assay, from the lowest: compound 2; then compound 1; then compound 3.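

In this assay, among the compounds shown here, exchanging the large substituent on a nitrogen on an aromatic ring for carboxymethyl gives a 2.9-fold higher number from compound 1 to compound 3 (0.47 log units; beyond the scatter) and so provides the first single-place comparison in this set. At this position, removing the six-membered aromatic ring and the rest of the large group while adding a short acid chain brings no gain in inhibition and instead gives a somewhat weaker inhibitor. The step is modest for such a large cut in size, and compound 3 still has a measurable value, so this one pair does not show the large group to be essential for inhibition. The data offer no measured explanation for the rise, and the loss of the large group and the arrival of the acid cannot be told apart from this single step.

The compounds shown leave open whether the higher number follows from the carboxylic acid itself or from the removal of the larger group. The methyl ester or primary amide of carboxymethyl would test the role of the acid at this nitrogen, while a longer chain ending in a carboxylic acid or a benzyl group would show how chain length and an aromatic ring affect the number.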